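Phenyl in Place of Acetyl on Compound 2

This account rests on a few compounds, and the source may have more. Where it says the series, first, only, none or still open, it means among the compounds named here.

Compound 1 `CC1CCCN1C1CCN(c2ccc(NC(=O)NC3CCCCC3)cc2)C1` gives 4.1 nM in an assay on CHO cells for displacement of a labelled ligand from histamine receptor H3 (Macaca mulatta), read by scintillation counting, with a stated time of 1 h; on this read-out lower numbers stand for stronger inhibition and higher numbers for weaker inhibition. Compound 2 `CC(=O)N1CCN(C(=O)Nc2ccc(N3CCC(N4CCCC4C)C3)cc2)CC1` gives 34.1 nM in this assay, the highest number shown, though only its gap to compound 1 lies beyond the scatter; compound 3 `CC(=O)N1CCN(C(=O)Nc2ccc(N3CCC(N4CCCC4C)C3)c(C)c2)CC1` gives 23 nM. The step of an 8.3-fold higher number from compound 1 to compound 2 (0.92 log units; beyond the scatter) is the only sizeable one, while a 1.5-fold lower number from compound 2 to compound 3 (0.17 log units; within the scatter) stays within the scatter. Compound 4 `CC1CCCN1C1CCN(c2ccc(NC(=O)N3CCN(c4ccccc4)CC3)cc2)C1` differs from compound 2 by phenyl in place of acetyl on an amine nitrogen in a ring. Within the data shown here, no measured step alters the group on that ring nitrogen itself; the step between compound 1 and compound 2 only shows that changes at the carbonyl end can move the number well beyond the scatter. Compound 4 is therefore expected to give a lower number, a 2.8-fold lower number from compound 2 to compound 4 (0.45 log units; beyond the scatter), though a result within the scatter cannot be excluded. The estimate for compound 4 is 12 nM, between 3 nM and 45 nM.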

Compound 4, inhibition constant: 10.6 nM
Compound 4: the middle estimate sits 1.1-fold (0.05 log units) above what was measured; the range from low to high includes it.
By their numbers in this assay, from the lowest: compound 1; then compound 4; then compounds 3 and 2 (each within the scatter of the next).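

Replacing the group on this ring nitrogen gives a 3.2-fold lower number from compound 2 to compound 4 (0.51 log units; beyond the scatter) in this assay, the first measured sign that this position itself can move the number beyond the scatter. The position accepts a six-membered aromatic ring of carbon only, and a hydrogen-bond acceptor at this spot is not required for a number of this size. No available evidence explains the change. As far as these compounds go, it remains open whether the step depends on the aromatic ring or on the loss of acetyl, and whether benzyl, pyridyl or a simple hydrogen on this nitrogen would give a similar number.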